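A Methyl Group on a Well-Tolerated Compound

The source may report more compounds than this note shows. Statements on the series, on what has been measured and on what is new or still open speak of the compounds shown alone.

In an ADME assay on MDBK cells (Bos taurus) for cytotoxicity, read by MTT assay, with a stated time of 96 h (a lower number here means that less compound is tolerated, a higher number that more compound is tolerated), compound 1 `Cc1ccc(/N=N/N(C)c2ccccc2)cc1` gives > 100000 nM, which is a limit of the test and not a number. Going by the values given here, compound 2 `CN(C)CCCN(/N=N/c1ccccc1)c1ccccc1` gives 95000 nM, the only actual number available so far, so there is no second number to rank it against.

Compound 3 `Cc1ccc(/N=N/N(CCCN(C)C)c2ccccc2)cc1` is compound 2 with one structural change: methyl in place of hydrogen on an aromatic carbon. Among the compounds with values here, no pair of measured compounds shows what this change does in this assay, so the data offer no direct guide to its size. A change of a single methyl group is expected to leave the result within the usual scatter of repeated measurements, with no clear direction. This expectation starts from compound 2 at 95000 nM. The estimated change is a 1.2-fold lower number from compound 2 to compound 3 (0.07 log units; within the scatter). Compound 3 is expected to give 80000 nM, with an estimated range from 35000 nM to 100000 nM.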

Compound 3, half-maximal cytotoxic concentration: > 100000 nM
Compound 3: only a limit was reported (the forecaster's own chance of this, stated with the estimate: 20%); middle value at least 1.2-fold (0.09 log units) away from the limit.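

Methyl in place of hydrogen on an aromatic carbon, para to a large group, gives an at least 1.0-fold higher number from compound 2 to compound 3 (0.02 log units; that floor lies within the scatter) in this assay, so this change from phenyl to 4-methylphenyl shows no sign of a lower number at this place. Compound 3 gives > 100000 nM, which is a limit of the assay and not a number. The step therefore has a floor but no top, so its true size stays unknown, and the same ceiling applies to most of the compounds shown: the limit of > 100000 nM in this assay, at which 2 of the 3 values shown sit.

The step from compound 1 to compound 3 cannot be read, with a limit at each end, so the compounds shown do not tell what the 2-(dimethylamino)ethyl part of the chain adds or removes in this test. As far as these compounds go, it also remains open whether a different group at this same place on the ring, such as a methoxy group, a chlorine atom or a carboxylic acid, would bring the result down to a number that can be read.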